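Propylsulfonyl to (Trifluoromethyl)carbonyl on a Shared Core

The source may hold more compounds than are shown below. What is called first, only, known or untested is meant among the compounds shown, and "the series" means these compounds.

Measured so far in an assay on isolated protein for binding affinity to Alpha-1D adrenergic receptor (Rattus norvegicus), read by radioligand binding; on this read-out higher numbers stand for weaker inhibition and lower numbers for stronger inhibition:
compound 1 `CCCS(=O)(=O)Nc1cccc2c1CCCC2c1c[nH]cn1`: < 10000 nM.
compound 2 `CCS(=O)(=O)Nc1cccc(C2CCNC2)c1`: 1000 nM.
compound 3 `COc1ccc2c(c1NS(C)(=O)=O)CCCC2c1c[nH]cn1`: 479 nM.

Compound 1 came back from the assay only as a limit, < 10000 nM, which is a threshold of the measurement rather than a number; this is the situation described by the limit of < 10000 nM in this assay, at which 1 of the 3 values shown sits. Compound 2 gives 1000 nM in this assay, and compound 3 gives 479 nM. None of these three differs from another in a single place, so no measured step can be read off, and the two numbers for compound 2 and compound 3 show only what they show.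

Compound 4 `O=C(Nc1cccc2c1CCCC2c1c[nH]cn1)C(F)(F)F` has not yet been measured. Against compound 1 it carries (trifluoromethyl)carbonyl in place of propylsulfonyl on a nitrogen on an aromatic ring. With compound 1 known only as a limit, the expected size of the step from it cannot be anchored; the expectation is that compound 4 lands somewhere inside the measurable range, as a step that the limit leaves unreadable from compound 1 to compound 4. Compound 4 is estimated at 3000 nM, with a range from 500 nM to 20000 nM.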

Compound 4, inhibition constant: 3310 nM
Estimate against measurement, compound 4: 1.1-fold (0.04 log units) below, within the range that was stated.
By their numbers in this assay, from the lowest: compound 3; then compound 2; then compound 4.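

Going by these compounds alone, compound 1 stands only as a limit, so no step from compound 1 to compound 4 can be read: the limit of < 10000 nM in this assay, at which 1 of the 4 values shown sits. The compounds shown leave open what (trifluoromethyl)carbonyl in place of propylsulfonyl on the shared core does to the value in this assay.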